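This account rests on a few compounds, and the source may have more. Where it says the series, first, only, none or still open, it means among the compounds named here.

Within the data shown here, compound 2 `Cc1ccc(S(=O)(=O)NCc2cn(C[C@H](O)[C@H]3OC(=O)C(OCc4ccccc4)=C3OCc3ccccc3)nn2)cc1` is the one compound here with a number rather than a limit: in a functional assay on CFPAC-1 cells (Homo sapiens) for antiproliferative activity, read by MTT assay, with a stated time of 72 h (on this read-out lower numbers stand for stronger inhibition and higher numbers for weaker inhibition), compound 2 gives 68000 nM. Compound 1 `COc1ccc(-c2cn(C/C=C3\OC(=O)C(OCc4ccccc4)=C3OCc3ccccc3)nn2)cc1` reaches only the limit of this assay, at > 100000 nM. Compound 3 `CCCCCc1ccc(-c2cn(C/C=C3\OC(=O)C(OCc4ccccc4)=C3OCc3ccccc3)nn2)cc1` also stops at the limit, at > 100000 nM. The change from compound 1 to compound 3, pentyl in place of methoxy on an aromatic carbon, therefore gives a step that cannot be read, a step that the two limits leave unreadable from compound 1 to compound 3, because both values sit at the limit of > 100000 nM in this assay, at which 2 of the 3 values shown sit.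

Compound 4 `O=C1O[C@H]([C@@H](O)Cn2cc(-c3ccc(Br)cc3)nn2)C(OCc2ccccc2)=C1OCc1ccccc1` has not yet been measured. It differs from compound 2 in one place: 4-bromophenyl in place of (((4-methylphenyl)sulfonyl)amino)methyl on an aromatic carbon. Among the measured compounds shown here, no measured step covers this change, so nothing shows whether a group of this kind on the shared core of compound 2 moves the number. The two compounds that carry an aryl group directly on the same ring, compound 1 and compound 3, sit at the limit, which points toward weak inhibition. Compound 4 is expected to give about 85000 nM, between 30000 nM and 250000 nM, a step from compound 2 of a 1.3-fold higher number from compound 2 to compound 4 (0.10 log units; within the scatter) in this assay.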

Compound 4, half-maximal inhibitory concentration: 5830 nM
Beside the measured number, compound 4's estimate is 15-fold (1.16 log units) above it; measured number below the stated range.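

Among these compounds, the position on the five-membered aromatic ring with 3 nitrogen responds strongly to the group it carries: in this assay, this change gives a 12-fold lower number from compound 2 to compound 4 (1.07 log units; beyond the scatter), the first step that can be read. The group that leaves holds a hydrogen-bond donor and hydrogen-bond acceptors, and 4-bromophenyl holds neither, so these atoms are not required for a number of this size on this core. Compound 1 and compound 3 differ from compound 4 in more than one place and offer no number to set against it: the limit of > 100000 nM in this assay, at which 2 of the 4 values shown sit.

On these data alone, this single change alters several things at once, so the share of the bromine in the step stays open. Plain phenyl, 4-chlorophenyl or 4-aminophenyl at this place on the core of compound 4 would separate the bromine from the ring that carries it.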